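A few compounds are considered here, and "the series" means these few. Any claim that something is new, unique, unknown or untested is made for them only; others in the source may bear on it.

Of the compounds shown here, three that share one core have been tested in a functional assay on MV4-11 cells (Homo sapiens) for inhibition, read by resazurin assay, with a stated time of 72 h; on this read-out lower numbers stand for stronger inhibition of growth and higher numbers for weaker inhibition of growth. Compound 1 `NS(=O)(=O)c1cccc(Nc2ncc3c(n2)CCCC3)c1` carries a sulfamoyl group on an aromatic carbon and gives 2550 nM. Compound 2 `COc1cccc(Nc2ncc3c(n2)CCCC3)c1` has methoxy at that place and gives 2280 nM. Compound 3 `CCc1cccc(Nc2ncc3c(n2)CCCC3)c1` has ethyl there and gives 2600 nM. Compound 3 therefore cannot be told apart from the other two, as all three values lie within the usual scatter of one another.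

Compound 4 `Cc1cccc(Nc2ncc3c(n2)CCCC3)c1` shortens the ethyl group of compound 3 to methyl: hydrogen in place of methyl on a saturated chain carbon bound to an aromatic carbon. In words, this is hydrogen in place of methyl on a saturated chain carbon bound to an aromatic carbon.

Among the compounds with values here, no measured step tests this exact change. The closest evidence comes from the swaps among the groups at the same place: a 1.0-fold higher number from compound 1 to compound 3 (0.01 log units; within the scatter), a 1.1-fold higher number from compound 2 to compound 3 (0.06 log units; within the scatter) and a 1.1-fold lower number from compound 1 to compound 2 (0.05 log units; within the scatter). Each of these lies within the scatter, even though sulfamoyl, methoxy and ethyl are quite different groups. On that basis, no change beyond the scatter is expected here, and the expected step is a 1.1-fold lower number from compound 3 to compound 4 (0.03 log units; within the scatter). The estimated value for compound 4 is 2400 nM, with an expected range of 1300 nM to 4300 nM.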

Compound 4, concentration for 50% growth inhibition: 3290 nM
For compound 4 the middle estimate is 1.4-fold (0.14 log units) below the measured one, and the stated range covers the measured number.
By their numbers in this assay, from the lowest: compounds 2, 1, 3 and 4 (each within the scatter of the next).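

Shortening ethyl to methyl, which puts hydrogen in place of methyl on a saturated chain carbon bound to an aromatic carbon, gives a step that stays within the scatter in this assay (a 1.3-fold higher number from compound 3 to compound 4 (0.10 log units; within the scatter)), so removing this single carbon has no effect that can be told from repeat-to-repeat variation. Methyl also cannot be separated from the two groups that differ most from it in makeup, as the swaps from sulfamoyl (a 1.3-fold higher number from compound 1 to compound 4 (0.11 log units; within the scatter)) and from methoxy (a 1.4-fold higher number from compound 2 to compound 4 (0.16 log units; within the scatter)) are likewise within the scatter, which extends the flat picture at this place from three groups to four. Nothing available here explains why these groups read alike.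

The compounds shown leave open whether any group at this place can move growth inhibition beyond the scatter, for example an amine, a carboxylic acid or a longer chain such as butyl. They also leave open whether changes elsewhere on the shared core would matter more than changes at this place.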